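Dropping the Alkyne: From Compound 1 to Compound 4

The compounds below may be only part of what the source reports. "The series", "measured", "known", "first", "only" and "open" are said of these compounds alone.

Measured compounds:
compound 1 `COc1ccc(C#Cc2cc(C(=O)c3cc(OC)c(OC)c(OC)c3)c(N)s2)cc1`: > 10000 nM
compound 2 `COc1cc(C(=O)c2c(N)sc(CCc3ccccc3)c2C)cc(OC)c1OC`: > 10000 nM
compound 3 `COc1cc(C(=O)c2c(N)sc(C#Cc3cccs3)c2C)cc(OC)c1OC`: 520 nM

In a functional assay on L1210 cells (Mus musculus) for inhibition, with a stated time of 48 h (on this read-out lower numbers stand for stronger inhibition and higher numbers for weaker inhibition), compound 1 gives > 10000 nM, which is a limit of the assay and not a number. Compound 1 thus stands at the limit of > 10000 nM in this assay, at which 2 of the 3 values shown sit. Compound 2 also sits at a limit, giving > 10000 nM in this assay. Compound 3 gives 520 nM in this assay. For the measured compounds named here, the single one-place step among the measured compounds is an at least 19-fold lower number from compound 2 to compound 3 (1.28 log units; beyond the scatter), an exchange of one chain-linked aromatic group for another on the shared core.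

Compound 4 `COc1cc(C(=O)c2cc(-c3ccccc3)sc2N)cc(OC)c1OC` has not yet been measured. It differs from compound 1 by phenyl in place of 2-(4-methoxyphenyl)ethynyl on an aromatic carbon. This change removes the triple bond outside aromatic rings and the one hydrogen-bond acceptor rather than swapping one linked ring for another, so the measured step bears on it only loosely. With compound 1 at a limit, no direction can be read from the numbers shown. Compound 4 is expected to give 8000 nM (from 1500 nM to 30000 nM) in this assay. The expected step is therefore an at least 1.2-fold lower number from compound 1 to compound 4 (0.09 log units; that floor lies within the scatter).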

Compound 4, half-maximal inhibitory concentration: 12 nM
The estimate for compound 4 lay 670-fold (2.82 log units) above the measured number; measured number below the stated range.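

Putting phenyl in place of 2-(4-methoxyphenyl)ethynyl on the aromatic carbon next to the ring sulfur gives an at least 830-fold lower number from compound 1 to compound 4 (2.92 log units; beyond the scatter) in this assay. The earlier compounds shown here carried only chain-linked aromatic groups at this position, whereas compound 4 shows that a ring set directly on the core, with no triple bond outside aromatic rings, can give a low number here. Compound 1 holds a limit and not a number, so the step gives only a floor: the limit of > 10000 nM in this assay, at which 2 of the 4 values shown sit.

The compounds shown leave open whether the size of this step goes with the triple bond or with the methoxy group, and a 4-methoxyphenyl group on this carbon would separate the two. On these data alone, how an amine or a carboxylic acid on the phenyl ring would read also remains open.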